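The source may hold more compounds than are shown below. What is called first, only, known or untested is meant among the compounds shown, and "the series" means these compounds.

Compound 1, `C=C1C(=O)OC[C@@H]1CCOC(=O)Nc1ccc(F)cc1F`, gives 700 nM in a functional assay on RAW264.7 cells (Mus musculus) for inhibition, with a stated time of 30 min; a higher number here means a weaker inhibitor, a lower number a stronger inhibitor.
Compound 2, `C=C1C(=O)OC[C@H]1CCOC(=O)Nc1ccccc1F`, gives 350 nM in this assay.

For the measured compounds named here, compound 2 holds the lower of the two numbers so far, but its gap to compound 1 lies within the scatter, so the two cannot be ranked. Compound 3, `C=C1C(=O)OC[C@H]1CCOC(=O)Nc1ccc(F)cc1F`, differs from compound 2 by fluoro in place of hydrogen on an aromatic carbon. Going by the values given here, no measured pair shows what such a change does in this assay, so the step from compound 2 to compound 3 is expected to be small, at most a modest weakening, and likely within the scatter. Compound 3 is therefore estimated at 600 nM, in a range from 250 nM to 1500 nM, which means an expected step of a 1.7-fold higher number from compound 2 to compound 3 (0.23 log units; within the scatter).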

Compound 3, half-maximal inhibitory concentration: 330 nM
Compound 3: middle estimate off by 1.8-fold (0.26 log units), on the high side; the range from low to high includes it.
By their numbers in this assay, from the lowest: compounds 3, 2 and 1 (each within the scatter of the next, the first and the last beyond it).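

In this assay, fluoro in place of hydrogen on this aromatic carbon, para to a large group, gives no readable difference, with a 1.1-fold lower number from compound 2 to compound 3 (0.03 log units; within the scatter), so the two compounds cannot be ranked. For the compounds shown here, the configuration at the ring carbon does register, though only modestly, with a 2.1-fold lower number from compound 1 to compound 3 (0.33 log units; beyond the scatter), the first single-place step beyond the scatter. Nothing else separates that pair: the fact that compounds 1 and 3 differ only in the configuration as drawn.

Going by these compounds, whether an amine or a methoxy group on this aromatic carbon would match fluoro stays open. So does whether configuration counts equally without the added fluoro.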